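The source may report more compounds than this note shows. Statements on the series, on what has been measured and on what is new or still open speak of the compounds shown alone.

Among the compounds with values here, compound 2 `COC(=O)C1=C(C)NC(C)=C(C(=O)OC(C)(C)C)C1c1[nH]cnc1Cl` holds the lowest of the two numbers measured so far in an assay on isolated protein for inhibition of Voltage-dependent L-type calcium channel subunit alpha-1C (Cavia porcellus); a lower number here means a stronger inhibitor, a higher number a weaker inhibitor: compound 2 gives 1860 nM, whereas its only measured neighbour, compound 1 `CC1=C(C(=O)OC(C)(C)C)C(c2[nH]cnc2Cl)C(C(=O)OC(C)(C)C)=C(C)N1`, gives 4070 nM. Within the data shown here, the single step separating them, a 2.2-fold lower number from compound 1 to compound 2 (0.34 log units; beyond the scatter), is modest but beyond the scatter. Compound 3 `CCOC(=O)C1=C(C)NC(C)=C(C(=O)OC(C)(C)C)C1c1[nH]cnc1Cl` is the next member of the series and carries methyl in place of hydrogen on a saturated chain carbon bound to an oxygen next to a carbonyl group. Among the measured compounds shown here, only that earlier step bears on this change, and it bears on it loosely, since the ethoxycarbonyl of compound 3 is longer by one carbon than the methoxycarbonyl of compound 2 yet shorter than the tert-butyl of compound 1. Because a larger change produced only a 2.2-fold lower number from compound 1 to compound 2 (0.34 log units; beyond the scatter), the smaller change here is expected to move this assay little, at most a slight rise that stays within the scatter, a 1.2-fold higher number from compound 2 to compound 3 (0.07 log units; within the scatter). Compound 3 is therefore estimated at 2200 nM, within a range of 1000 nM to 4800 nM.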

Compound 3, half-maximal inhibitory concentration: 1660 nM
Compound 3: the middle estimate sits 1.3-fold (0.12 log units) above what was measured, and the stated range covers the measured number.
By their numbers in this assay, from the lowest: compounds 3 and 2 (each within the scatter of the next); then compound 1.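

In this assay, the change from methoxycarbonyl to ethoxycarbonyl gives a 1.1-fold lower number from compound 2 to compound 3 (0.05 log units; within the scatter), so the added methyl on the saturated chain carbon bound to an oxygen does not separate these two compounds. Ethyl in place of tert-butyl gives a 2.5-fold lower number from compound 1 to compound 3 (0.39 log units; beyond the scatter), which is beyond the scatter, as is a 2.2-fold lower number from compound 1 to compound 2 (0.34 log units; beyond the scatter), so among the three groups on this oxygen only tert-butyl stands apart, with methyl and ethyl level with each other. No evidence is available on what lies behind these steps.

The compounds shown leave open whether a longer chain such as propyl or butyl on this oxygen would stay level with methyl and ethyl. They also leave open how a carboxylic acid or an amide in place of this ester would read.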